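A few compounds are considered here, and "the series" means these few. Any claim that something is new, unique, unknown or untested is made for them only; others in the source may bear on it.

Compound 1 `CCCCCC(=O)Nc1ccc(S(=O)(=O)Oc2ccccc2C(C)C)cc1`: 6400 nM
Compound 2 `CC(C)c1ccccc1OS(=O)(=O)c1ccc(NC(=O)C(C)(C)C)cc1`: 15000 nM
Compound 3 `CC(C)c1ccccc1OS(=O)(=O)c1ccc(NC(=O)CCl)cc1`: 5600 nM

These three compounds share the same core and differ only in the group attached to the carbonyl carbon of the amide. Going by the values given here, in a functional assay on HT-29 cells (Homo sapiens) for antiproliferative activity, read by sulforhodamine B assay, with a stated time of 48 h (on this read-out higher numbers stand for weaker inhibition and lower numbers for stronger inhibition), compound 3 gives the lowest number of the three, but the step of a 1.1-fold lower number from compound 1 to compound 3 (0.06 log units; within the scatter) lies within the scatter, so compounds 1 and 3 cannot be told apart on this read-out; only the step of a 2.7-fold lower number from compound 2 to compound 3 (0.43 log units; beyond the scatter) is beyond it.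

Compound 4 `CC(C)c1ccccc1OS(=O)(=O)c1ccc(NC(=O)NC2CCCC2)cc1` has not yet been measured. It differs from compound 3 by cyclopentylamino in place of chloromethyl on a carbonyl carbon: the (chloromethyl)carbonyl becomes a cyclopentylcarbamoyl. Among the compounds with values here, no measured pair makes this same change. The nearest guides are a 2.3-fold higher number from compound 1 to compound 2 (0.37 log units; beyond the scatter) and a 2.7-fold lower number from compound 2 to compound 3 (0.43 log units; beyond the scatter), which show that the branched tert-butyl on the carbonyl carbon gave a modestly higher number than either pentyl or chloromethyl. Cyclopentylamino also departs from a straight chain, and it brings a hydrogen-bond donor that none of the measured groups has, so these steps are only an indirect guide. On this basis the expected step is a 1.4-fold higher number from compound 3 to compound 4 (0.15 log units; within the scatter), a modestly higher number. For compound 4 the estimated value in this assay is 8000 nM, with a range from 2500 nM to 30000 nM.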

Compound 4, half-maximal inhibitory concentration: 7400 nM
Compound 4: middle estimate off by 1.1-fold (0.03 log units), on the high side, within the range that was stated.
By their numbers in this assay, from the lowest: compounds 3, 1 and 4 (each within the scatter of the next); then compound 2.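

Compound 4 puts both a ring and a hydrogen-bond donor on the carbonyl carbon, yet in this assay neither comparison with the smaller or unbranched groups rises above the scatter: a 1.3-fold higher number from compound 3 to compound 4 (0.12 log units; within the scatter) and a 1.2-fold higher number from compound 1 to compound 4 (0.06 log units; within the scatter). The cyclopentylamino group therefore sits alongside chloromethyl and pentyl on this read-out, while the tert-butyl group stays apart, as shown by a 2.0-fold lower number from compound 2 to compound 4 (0.31 log units; beyond the scatter). So this position tolerates a change from an amide to a cyclopentylcarbamoyl group with no detectable shift, but no measurement available here explains any of these values.

Cyclopentylamino brings in the ring and the nitrogen with its hydrogen together, so these compounds cannot show which of the two matters; a cyclopentyl group bound directly to the carbonyl carbon, or an open-chain pentylamino group, would help separate them. Going by these compounds, it also remains open whether a quite different group at this position, such as a phenylamino group or a chain ending in a carboxylic acid or an amine, could move the number well beyond the narrow span seen so far.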